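Rearranging the Chloro and Cyano Groups in Compound 3

A few compounds are considered here, and "the series" means these few. Any claim that something is new, unique, unknown or untested is made for them only; others in the source may bear on it.

In a functional assay on MCF7 cells (Homo sapiens) for antiproliferative activity, read by CellTiter-Glo, with a stated time of 5 days (a lower number here means a stronger inhibitor, a higher number a weaker inhibitor), compound 1 `O=C(O)/C=C/c1ccc(/C(=C(\c2ccc(F)cc2Cl)C2CCC2)c2ccc(-c3cncs3)cc2)cc1` gives 4.2 nM and compound 2 `N#Cc1ccc(/C(=C(\c2ccc(/C=C/C(=O)O)cc2)c2ccc(-c3cncs3)cc2)C2CCC2)c(Cl)c1` gives 2.9 nM. These two numbers lie within the scatter of each other, so compound 2 stands level with compound 1. For the measured compounds named here, the one measured step, a 1.4-fold lower number from compound 1 to compound 2 (0.16 log units; within the scatter), is cyano in place of fluoro on an aromatic carbon, and it stays within the scatter.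

Compound 3 `N#Cc1cc(Cl)ccc1/C(=C(\c1ccc(/C=C/C(=O)O)cc1)c1ccc(-c2cncs2)cc1)C1CCC1` keeps the atoms of compound 2 but joins them differently: 4-chloro-2-cyanophenyl in place of 2-chloro-4-cyanophenyl on a double-bonded chain carbon bound to a double-bonded chain carbon and a saturated ring carbon. The change sits on a double-bonded chain carbon bound to a double-bonded chain carbon and a saturated ring carbon. Going by the values given here, the measured step bears on this only in part, since it exchanges one group for another, and no measured pair shows a rearrangement like this one. The evidence is thin, but on the strength of a 1.4-fold lower number from compound 1 to compound 2 (0.16 log units; within the scatter) no shift beyond the scatter is expected in this assay. The estimated change is a 1.4-fold higher number from compound 2 to compound 3 (0.14 log units; within the scatter), which would remain within the scatter. Compound 3 is expected at 4 nM, with an estimated range from 1.5 nM to 12 nM.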

Compound 3, half-maximal inhibitory concentration: 4.3 nM
Compound 3: the middle estimate sits 1.1-fold (0.03 log units) below what was measured, within the range that was stated.
By their numbers in this assay, from the lowest: compounds 2, 1 and 3 (each within the scatter of the next).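

Exchanging the places of the chloro and cyano groups on this ring now has a measured result: in this assay, 4-chloro-2-cyanophenyl in place of 2-chloro-4-cyanophenyl gives a 1.5-fold higher number from compound 2 to compound 3 (0.17 log units; within the scatter) and so stays within the scatter. Compared with the fluoro-bearing ring, 4-chloro-2-cyanophenyl in place of 2-chloro-4-fluorophenyl gives a 1.0-fold higher number from compound 1 to compound 3 (0.01 log units; within the scatter) and also stays within the scatter, so the three aromatic groups shown on this double-bonded chain carbon stand level with one another in this assay. Nothing available here explains why these three groups read alike.

All three groups carry a chloro group, so the compounds shown leave open whether the level readings would hold on a ring with a methoxy group or an amine in its place. They also leave open whether a plain phenyl ring, with neither chloro nor cyano, would stay level with compound 2 and compound 3.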